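The compounds below may be only part of what the source reports. "The series", "measured", "known", "first", "only" and "open" are said of these compounds alone.

Working notes on the series. Compound 1 `O=C(N1CCCN(Cc2ccc(OCc3ccccc3)cc2)CC1)n1cccn1` and compound 2 `N#Cc1cnn(C(=O)N2CCCN(Cc3ccc(OCc4ccccc4)cc3)CC2)c1` share one core and differ by a single change, (cyano in place of hydrogen on an aromatic carbon). In an assay on membranes from brain for binding affinity to Monoacylglycerol lipase ABHD6 (Mus musculus), read by fluorescence, with stated times of 1 h and 30 min (a lower number here means a stronger inhibitor, a higher number a weaker inhibitor), compound 1 gives 960 nM, and compound 2 gives 85 nM; the change produced an 11-fold lower number from compound 1 to compound 2 (1.05 log units; beyond the scatter). Compound 3 `CN(CCN(C)C(c1ccc(OCc2ccccc2)cc1)c1ccc(OCc2ccccc2)cc1)C(=O)n1cccn1` carries a different core; the difference between the two cores is not broken down here. In this assay compound 3 gives only a limit, > 1000000 nM, and no number. This is the limit of > 1000000 nM in this assay, at which 1 of the 3 values shown sits.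

Compound 4 `CN(CCN(C)C(c1ccc(OCc2ccccc2)cc1)c1ccc(OCc2ccccc2)cc1)C(=O)n1cc(C#N)cn1` is not yet measured. It differs from compound 3 by cyano in place of hydrogen on an aromatic carbon, the same change, at the same place, as between compound 1 and compound 2. An expected step of an at least 3.3-fold lower number from compound 3 to compound 4 (0.52 log units; beyond the scatter) is set for this assay, resting on the measured step of an 11-fold lower number from compound 1 to compound 2 (1.05 log units; beyond the scatter). The starting point is itself a limit for compound 3, so the absolute level is uncertain and a limit may again be reported. Compound 4 is expected at 300000 nM in this assay, within a range from 30000 nM to 3000000 nM.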

Compound 4, half-maximal inhibitory concentration: > 1000000 nM
Compound 4 ended at the assay's limit; the forecaster's own chance of this, stated with the estimate: 55%; middle value at least 3.3-fold (0.52 log units) from the limit.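

Compound 3 and compound 4 each give only a limit in this assay, so no step can be read between them: the limit of > 1000000 nM in this assay, at which 2 of the 4 values shown sit.

The compounds shown leave open whether cyano in place of hydrogen on an aromatic carbon changes the number at all on the core of compound 3, as it does on the core of compound 1.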